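The source may hold more compounds than are shown below. What is called first, only, known or untested is meant among the compounds shown, and "the series" means these compounds.

Among the measured compounds shown here, compound 2 `Cc1cc(-c2cc(Cl)cc(Cl)c2/C=C/[C@@H]2C[C@@H](O)CC(=O)O2)ccc1F` stands lowest of the three numbers so far in an assay for inhibition of 3-hydroxy-3-methylglutaryl-coenzyme A reductase (Rattus norvegicus); a lower number here means a stronger inhibitor, a higher number a weaker inhibitor. Compound 3 `Cc1cc(F)ccc1-c1cc(Cl)cc(Cl)c1/C=C/[C@@H]1C[C@@H](O)CC(=O)O1` is its nearest neighbour: the difference a 1.2-fold higher number from compound 2 to compound 3 (0.09 log units; within the scatter) lies within the scatter, so the two cannot be ordered. Compound 1 `COc1ccc(-c2cc(Cl)cc(Cl)c2/C=C/[C@@H]2C[C@@H](O)CC(=O)O2)cc1` lies furthest away; compound 1 gives 470 nM, compound 2 gives 29 nM and compound 3 gives 36 nM in this assay.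

Compound 4 `Cc1cc(Cl)c(/C=C/[C@@H]2C[C@@H](O)CC(=O)O2)c(-c2ccc(F)c(C)c2)c1` is not yet measured. It differs from compound 2 by methyl in place of chloro on an aromatic carbon. For the measured compounds named here, none of the measured steps touches this position. Going by the values given here, the two large steps, a 16-fold lower number from compound 1 to compound 2 (1.21 log units; beyond the scatter) and a 13-fold lower number from compound 1 to compound 3 (1.12 log units; beyond the scatter), both change the aryl group on the shared core, and the one small step, a 1.2-fold higher number from compound 2 to compound 3 (0.09 log units; within the scatter), moves a methyl within that aryl group. What a methyl in place of a chloro on the core itself does is therefore not shown by any pair here, and the expectation rests only on the retained 4-fluoro-3-methylphenyl group, which compound 2 and compound 3 share with their low numbers.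

Given that, compound 4 is expected to stay close to compound 2, with a step of a 1.4-fold higher number from compound 2 to compound 4 (0.14 log units; within the scatter) that is estimated to fall within the scatter or slightly beyond it. The estimate for compound 4 in this assay is 40 nM, with a range from 15 nM to 120 nM.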

Compound 4, half-maximal inhibitory concentration: 13 nM
Estimate against measurement, compound 4: 3.1-fold (0.49 log units) above; the measured number lies below the stated range.
By their numbers in this assay, from the lowest: compound 4; then compounds 2 and 3 (each within the scatter of the next); then compound 1.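

In this assay, the position on the shared core that is meta to the 4-fluoro-3-methylphenyl group tolerates more than one substituent, and the chloro group there is not needed for a low number: a 2.2-fold lower number from compound 2 to compound 4 (0.35 log units; beyond the scatter), with methyl in place of chloro, is a modest step beyond the scatter. Among the compounds shown here, every earlier step changed or rearranged the aryl group, so this is the first sign that the substituents on the core itself can move the number, here towards a stronger inhibitor. No measurement shown here accounts for the difference between chloro and methyl at this position.

This reading rests on a single pair, so the compounds shown leave open whether the same exchange would lower the number with the 4-fluoro-2-methylphenyl group of compound 3 or the 4-methoxyphenyl group of compound 1. They also leave open how an ethyl, methoxy or amine group would compare at this position, and what the same exchange would do to the other chloro group on the core.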